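Ethyl to propyl on the hydroxyurea nitrogen

This account rests on a few compounds, and the source may have more. Where it says the series, first, only, none or still open, it means among the compounds named here.

Measured compounds:
compound 1, `CCCOc1c(NC(=O)N(O)C2CCCCC2)cc(C2CCC(c3cc(OC)c(OC)c(OC)c3)O2)cc1OC`, 1000 nM; 278 nM (2 entries)
compound 2, `CCCOc1cc([C@H]2CC[C@H](c3cc(OC)c(OC)c(OC)c3)O2)cc(N(CC)C(=O)N(O)CC)c1OCCC`, 17 nM

In an assay for binding affinity to platelet-activating factor receptor (Homo sapiens) (on this read-out higher numbers stand for weaker inhibition and lower numbers for stronger inhibition), compound 1 gives 1000 nM; 278 nM (2 entries) across two entries, while compound 2 gives 17 nM, the only number shown for it; one further entry for compound 2 carries no single number. Compound 3, `CCCOc1cc([C@H]2CC[C@H](c3cc(OC)c(OC)c(OC)c3)O2)cc(N(CC)C(=O)N(O)CCC)c1OCCC`, is not yet measured. It differs from compound 2 by methyl in place of hydrogen on a saturated chain carbon, two bonds along the chain from an amide-type nitrogen. Among the compounds with values here, no step between measured compounds is given for guidance. The change is expected to leave this assay largely unchanged, within the usual scatter, and the step of a 1.2-fold higher number from compound 2 to compound 3 (0.07 log units; within the scatter) is estimated accordingly. Compound 3 is therefore expected to give 20 nM, with a range from 7 nM to 60 nM.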

Compound 3, half-maximal inhibitory concentration: 56 nM
Estimate against measurement, compound 3: 2.8-fold (0.45 log units) below; the range from low to high includes it.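

Ethyl to propyl, on a saturated chain carbon two bonds along the chain from an amide-type nitrogen, gives a 3.3-fold higher number from compound 2 to compound 3 (0.52 log units; beyond the scatter) in this assay, so this position responds to a single added methyl. The earlier compounds shown here offered no step at all that could show this. The step is modest, and separate entries for one compound can lie well apart in this assay: the several entries of compound 1 in this assay, 1000 nM; 278 nM (2 entries)

From the compounds shown here alone, with only ethyl and propyl compared here, it remains open whether a longer chain such as butyl would weaken inhibition further. Going by these compounds, how a branched isopropyl or a terminal hydroxyl or amine on the chain would read also remains open.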